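Cyclohexyl for Benzyl: Expected Solubility of Compound 4

This account rests on a few compounds, and the source may have more. Where it says the series, first, only, none or still open, it means among the compounds named here.

Measured so far:
Compound 1 `c1ccc(CCc2ccc3c(NCCCNCc4ccco4)ccnc3c2)cc1` gives 4200 nM in a physicochemical assay for solubility, with a stated time of 18 h, at pH 7.4; on this read-out higher numbers stand for higher solubility and lower numbers for lower solubility.
Compound 2 `c1coc(CNCCCNc2ccnc3cc(CC4CCCCC4)ccc23)c1` gives 4200 nM in this assay.
Compound 3 `COc1cccc(CNCCCNc2ccnc3cc(CCc4ccccc4)ccc23)c1O` gives 4200 nM in this assay.

Compound 2 differs from compound 1 by cyclohexyl in place of benzyl on a saturated chain carbon bound to an aromatic carbon, and the step is no change at the digits printed from compound 1 to compound 2 (within the scatter). Compound 3 differs from compound 1 by 2-hydroxy-3-methoxyphenyl in place of furan-2-yl on a saturated chain carbon bound to an amine nitrogen, with the step of no change at the digits printed from compound 1 to compound 3 (within the scatter). Among the measured compounds shown here, compound 4 `COc1cccc(CNCCCNc2ccnc3cc(CC4CCCCC4)ccc23)c1O` is not yet measured; it differs from compound 3 by cyclohexyl in place of benzyl on a saturated chain carbon bound to an aromatic carbon, which is the same change, at the same place, as the one from compound 1 to compound 2. The two cores of these pairs differ by 2-hydroxy-3-methoxyphenyl in place of furan-2-yl on a saturated chain carbon bound to an amine nitrogen.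

Because the earlier step of no change at the digits printed from compound 1 to compound 2 (within the scatter) was flat, the step from compound 3 to compound 4 is expected to be no change at the digits printed from compound 3 to compound 4 (within the scatter). Compound 4 is therefore estimated at 4200 nM in this assay, most likely between 2000 nM and 8400 nM.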

Compound 4, solubility: 4200 nM
For compound 4 middle estimate and measured number coincide at the digits printed; measured number inside the range.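

Cyclohexyl in place of benzyl carries over flat: in this assay the step on the second core is no change at the digits printed from compound 3 to compound 4 (within the scatter) and so reads like the step on the first core, no change at the digits printed from compound 1 to compound 2 (within the scatter) in that case. The other change, 2-hydroxy-3-methoxyphenyl in place of furan-2-yl, also stays flat with cyclohexyl present, the step being no change at the digits printed from compound 2 to compound 4 (within the scatter) for this pair. This shows a flat change staying flat on two cores, but not that it would on any other core, nor how a change that moves the number would carry over.

Still open, as far as these compounds go, is what a carboxylic acid, an amine or a longer chain would do on the saturated chain carbon bound to an aromatic carbon. Also open is why all four values stand level, as no measurement here bears on that.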